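This account rests on a few compounds, and the source may have more. Where it says the series, first, only, none or still open, it means among the compounds named here.

Compound 1 `Cc1nc(C(NC(=O)C(=O)Nc2ccc(F)c(Cl)c2)C2CCCCN2)sc1CO`: > 77800 nM
Compound 2 `Cc1nc(C(NC(=O)C(=O)Nc2ccc(F)c(F)c2)C2CCCCN2)sc1CO`: > 87000 nM

Both entries come from an ADME assay on MT2 cells (Homo sapiens) for cytotoxicity, read by XTT assay, with a stated time of 4 days (a higher number here means that more compound is tolerated, a lower number that less compound is tolerated), and both are limits rather than numbers. Compound 2 therefore stands only at its limit of > 87000 nM, with no exact value known. Within the data shown here, the one measured step, fluoro in place of chloro on an aromatic carbon, is a step that the two limits leave unreadable from compound 1 to compound 2. It gives no size that could be carried forward.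

Compound 3 `CC(=O)c1ccc(NC(=O)C(=O)NC(c2nc(C)c(CO)s2)C2CCCCN2)cc1` keeps the shared core and changes the group on the amide-type nitrogen, with 4-acetylphenyl in place of 3,4-difluorophenyl on an amide-type nitrogen. This is a different change from the measured one, so that step offers only weak guidance. With no readable size to go on, no step beyond the usual scatter is expected in this assay, and no direction can be assigned. The expected change is an at least 1.0-fold lower number from compound 2 to compound 3 (0.01 log units; that floor lies within the scatter). For compound 3 the estimate is 85000 nM, with an expected range of 35000 nM to 170000 nM. A limit rather than a number is the likely report for compound 3 as well.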

Compound 3, half-maximal cytotoxic concentration: > 107000 nM
Compound 3: only a limit was reported (the forecaster's own chance of this, stated with the estimate: 75%); at least 1.2-fold (0.09 log units) between middle value and limit.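

In this assay compound 3 gives > 107000 nM, which is a limit and not a number. Among these compounds, compound 1, compound 2 and compound 3 are all reported only as limits, and no step among them can be read. The compounds shown leave open at what concentration each becomes toxic to the cells, and whether the group on the amide-type nitrogen changes that concentration.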